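The source may hold more compounds than are shown below. What is called first, only, known or untested is meant among the compounds shown, and "the series" means these compounds.

Measured compounds:
compound 1 `Cc1nc(-c2ccccc2)c(C(=O)N2CCN(c3cccc(C(N)=O)c3)CC2)o1` — 71 nM
compound 2 `Cc1nc(-c2ccccc2)c(C(=O)N2CCN(c3ccc(C)c(C)c3)CC2)o1` — 43 nM
compound 3 `COc1cc(OC)cc(N2CCN(C(=O)c3oc(C)nc3-c3ccccc3)CC2)c1` — 19.2 nM

The three compounds share one core and differ only in the aryl group carried on an amine nitrogen in a ring. In a functional assay on HL-60 cells (Homo sapiens) for inhibition, read by MTT assay, with a stated time of 72 h (on this read-out lower numbers stand for stronger inhibition and higher numbers for weaker inhibition), compound 3 holds the lowest number of the three. Its distance to the others is beyond the scatter in both cases: a 2.2-fold lower number from compound 2 to compound 3 (0.35 log units; beyond the scatter) and a 3.7-fold lower number from compound 1 to compound 3 (0.57 log units; beyond the scatter), whereas a 1.7-fold lower number from compound 1 to compound 2 (0.22 log units; within the scatter) lies within the scatter.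

Compound 4 `CCOc1cccc(N2CCN(C(=O)c3oc(C)nc3-c3ccccc3)CC2)c1` is the next step from compound 3. The change is 3-ethoxyphenyl in place of 3,5-dimethoxyphenyl on an amine nitrogen in a ring. Within the data shown here, no measured pair shows exactly this kind of change, so the two steps that end at compound 3 are the only guide, and both are modest. Since compound 3 gives 19.2 nM with 3,5-dimethoxyphenyl while compound 2 with 3,4-dimethylphenyl gives 43 nM, a move to 3-ethoxyphenyl is expected to cost some of that advantage, landing between the two, with a step of a 1.7-fold higher number from compound 3 to compound 4 (0.22 log units; within the scatter) expected. Compound 4 is therefore estimated at 32 nM in this assay, with a range from 12 nM to 85 nM.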

Compound 4, half-maximal inhibitory concentration: 151 nM
Compound 4: the middle estimate sits 4.7-fold (0.67 log units) below what was measured; the whole stated range lies below it.
By their numbers in this assay, from the lowest: compound 3; then compounds 2 and 1 (each within the scatter of the next); then compound 4.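

At this position, on an amine nitrogen in a ring, replacing 3,5-dimethoxyphenyl with 3-ethoxyphenyl is not a neutral exchange in this assay (a 7.9-fold higher number from compound 3 to compound 4 (0.90 log units; beyond the scatter)), and it carries compound 4 beyond the scatter of every other compound shown, making it the weakest of the four. The loss is not limited to the comparison with the best compound, as 3-ethoxyphenyl also falls behind 3,4-dimethylphenyl (a 3.5-fold higher number from compound 2 to compound 4 (0.55 log units; beyond the scatter)) and 3-carbamoylphenyl (a 2.1-fold higher number from compound 1 to compound 4 (0.33 log units; beyond the scatter)), so the aryl groups on this nitrogen spread more widely than the first three compounds suggested. Nothing available explains why this group gives the highest number of the series.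

The compounds shown cannot separate the effect of the ethoxy chain from that of having only one group on the aromatic ring, a question that 3-methoxyphenyl or 3,5-diethoxyphenyl on the same nitrogen would address. They also leave open how a hydroxy group, an amine or a longer chain such as propoxy on that aromatic ring would read in this assay.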